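Replacing Methylamino at the Aromatic Carbon of the Core

The source may hold more compounds than are shown below. What is called first, only, known or untested is meant among the compounds shown, and "the series" means these compounds.

Compound 1, `CNC(=O)[C@@]12C[C@@H]1[C@@H](n1cnc3cnc(C#Cc4ccc(Cl)s4)nc31)[C@H](O)[C@@H]2O`, gives a limit of < 10% in an assay on CHO cells for displacement of a labelled ligand from adenosine receptor A1 (Homo sapiens), read by scintillation counting, with a stated time of 60 min, tested at 10 uM; on this read-out higher numbers stand for more inhibition at the one concentration tested (going by the name of the read-out) and lower numbers for less inhibition. Compound 2, `CNC(=O)[C@@]12C[C@@H]1[C@@H](n1cnc3cnc(NC)nc31)[C@H](O)[C@@H]2O`, gives 17% in this assay. Compound 3, `CNC(=O)[C@@]12C[C@@H]1[C@@H](n1cnc3c(/C=C(\O)c4ccc(C(C)(C)C)cc4)nc(C#Cc4ccc(C(C)(C)C)cc4)nc31)[C@H](O)[C@@H]2O`, gives 24% in this assay.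

Among the two numbers shown, compound 2 stands lowest; compound 3 lies close to it, the gap within the usual scatter, and the remaining value is a limit. Among the compounds with values here, the only single-point step touching compound 2 is a number at least 7 percentage points higher from compound 1 to compound 2 (that floor lies within the scatter), where the starting value is a limit (the limit of < 10% in this assay, at which 1 of the 3 values shown sits).

Compound 4, `CNC(=O)[C@@]12C[C@@H]1[C@@H](n1cnc3cnc(/C=C(\O)c4cnccn4)nc31)[C@H](O)[C@@H]2O`, has not been measured. It differs from compound 2 by 2-hydroxy-2-(pyrazin-2-yl)ethenyl in place of methylamino on an aromatic carbon. The step from compound 1 to compound 2 bears on the same aromatic carbon and was a small change, but it ran in the opposite direction, from an ethynyl group to methylamino, so it gives only a loose guide here. With compound 3 also low, no step beyond the scatter is expected, and the estimated change is a number 1 percentage points lower from compound 2 to compound 4 (within the scatter). Compound 4 is therefore expected to give about 16% in this assay, estimated between 4% and 34%.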

Compound 4, a percentage reported as inhibition, at one concentration (the size of the read-out at that concentration, not a potency): 14%
Compound 4: middle estimate off by 2 percentage points, on the high side; the range from low to high includes it.
By their numbers in this assay, from the lowest: compounds 4, 2 and 3 (each within the scatter of the next). At a limit, below all of these: compound 1.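

On the aromatic carbon between two ring nitrogen atoms, 2-hydroxy-2-(pyrazin-2-yl)ethenyl, which brings a six-membered aromatic ring, takes the place of methylamino in this assay with a number 3 percentage points lower from compound 2 to compound 4 (within the scatter) as the result. The same position thus carries a far bigger group, with a ring, and the number stays within the scatter of the methylamino value. Set against the ethynyl group of compound 1, the change gives a number at least 4 percentage points higher from compound 1 to compound 4 (that floor lies within the scatter) and starts from a limit: the limit of < 10% in this assay, at which 1 of the 4 values shown sits.

The compounds shown leave open whether a primary amine, a carboxylic acid or a longer chain on this aromatic carbon would move the number beyond the scatter. They also leave open what a phenyl ring in place of the pyrazin-2-yl ring would do.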